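The compounds below may be only part of what the source reports. "The series", "measured", "known", "first", "only" and "open" are said of these compounds alone.

Compounds measured in an ADME assay on Vero cells (Chlorocebus sabaeus) for cytotoxicity, read by luminescence, with a stated time of 2 days; on this read-out higher numbers stand for lower toxicity in this test and lower numbers for higher toxicity in this test:
- compound 1 `CCc1nc2ccccc2n1CCCCOc1cccc(C)c1`: 19 uM
- compound 2 `CCc1nc2ccccc2n1CCCCOc1cccc(Cl)c1`: 22 uM
- compound 3 `CCc1nc2ccccc2n1CCCCOc1ccc(Cl)cc1F`: 5.7 uM

Compound 1 stands second highest of the three numbers. Its nearest neighbour is compound 2, and that step, a 1.2-fold higher number from compound 1 to compound 2 (0.06 log units; within the scatter), is within the scatter, so nothing is read into the order of these two. Its furthest neighbour is compound 3, reached by a 3.3-fold lower number from compound 1 to compound 3 (0.52 log units; beyond the scatter).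

The unmeasured compound 4 `CCc1nc2ccccc2n1CCCCOc1ccc(Cl)cc1C` differs from compound 1 in one place: 4-chloro-2-methylphenyl in place of 3-methylphenyl on an oxygen on a saturated carbon.

Within the data shown here, two measured steps bear on this change. The step of a 3.3-fold lower number from compound 1 to compound 3 (0.52 log units; beyond the scatter) and the step of a 3.9-fold lower number from compound 2 to compound 3 (0.59 log units; beyond the scatter) both put a 4-chloro substituted ring with a further group in place of a ring carrying a single substituent, and both gave a modest move toward lower numbers in this assay. The step of a 1.2-fold higher number from compound 1 to compound 2 (0.06 log units; within the scatter) shows that chloro against methyl on the aromatic carbon made no difference beyond the scatter. Compound 4 shares the 4-chloro pattern with compound 3, so a step of the same kind and direction is expected, and compound 4 is therefore estimated at 7 uM, with a range of 3 uM to 16 uM, which means an expected step of a 2.7-fold lower number from compound 1 to compound 4 (0.43 log units; beyond the scatter).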

Compound 4, half-maximal toxic concentration: 20 uM
Estimate against measurement, compound 4: 2.9-fold (0.46 log units) below; the measured number lies above the stated range.
By their numbers in this assay, from the lowest: compound 3; then compounds 1, 4 and 2 (each within the scatter of the next).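

In this assay, the 4-chloro pattern alone does not bring the lower number seen with compound 3: 4-chloro-2-methylphenyl in place of 3-methylphenyl gives no readable shift (a 1.1-fold higher number from compound 1 to compound 4 (0.02 log units; within the scatter)), and the same holds for 4-chloro-2-methylphenyl in place of 3-chlorophenyl (a 1.1-fold lower number from compound 2 to compound 4 (0.04 log units; within the scatter)). The only new step beyond the scatter is methyl in place of fluoro on an aromatic carbon (a 3.5-fold higher number from compound 3 to compound 4 (0.55 log units; beyond the scatter)), so among these four compounds the lower number stands with the 4-chloro-2-fluorophenyl of compound 3 alone, while compounds 1, 2 and 4 stay within the scatter of one another. Nothing available gives a cause for this difference between fluoro and methyl.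

Still open, going by these compounds, is whether fluoro gives the lower number on a ring without the chloro, or only together with it. Equally open, on these data alone, is how a methoxy, a trifluoromethyl or an amine would read in this assay in the place held by methyl in compound 4 and by fluoro in compound 3.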